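The source may report more compounds than this note shows. Statements on the series, on what has been measured and on what is new or still open speak of the compounds shown alone.

Measured compounds:
compound 1, `Nc1nc(N)c2cc(CSC(=S)N3CCN(c4ccccc4)CC3)ccc2n1`: 2950 nM
compound 2, `Nc1nc(N)c2cc(CSC(=S)N3CCN(c4ccc(O)cc4)CC3)ccc2n1`: 5090 nM
compound 3, `Nc1nc(N)c2cc(CSC(=S)N3CCN(c4ccc(F)cc4)CC3)ccc2n1`: 1920 nM

In a functional assay on MCF7 cells (Homo sapiens) for antiproliferative activity, read by MTT assay, with a stated time of 72 h (on this read-out higher numbers stand for weaker inhibition and lower numbers for stronger inhibition), compound 2 gives 5090 nM, the highest of the three numbers; compound 1 lies nearest, with a 1.7-fold higher number from compound 1 to compound 2 (0.24 log units; within the scatter), and compound 3 lies furthest, with a 2.7-fold lower number from compound 2 to compound 3 (0.42 log units; beyond the scatter). Compound 4, `Nc1nc(N)c2cc(CSC(=S)N3CCN(c4ccc(F)cc4F)CC3)ccc2n1`, has not yet been measured in this assay. It differs from compound 2 in one place: 2,4-difluorophenyl in place of 4-hydroxyphenyl on an amine nitrogen in a ring. For the measured compounds named here, two measured steps bear on this change. Putting a fluoro in place of hydrogen gave a 1.5-fold lower number from compound 1 to compound 3 (0.19 log units; within the scatter), and putting a fluoro in place of hydroxy gave a 2.7-fold lower number from compound 2 to compound 3 (0.42 log units; beyond the scatter). Going by the values given here, no measured compound carries a 2,4-difluorophenyl, so the second fluoro is an untested addition. The step from compound 2 is nevertheless expected to resemble the modest lowering seen toward compound 3, an estimated 3.0-fold lower number from compound 2 to compound 4 (0.48 log units; beyond the scatter). Compound 4 is therefore expected to give about 1700 nM in this assay, within a range of 800 nM to 3600 nM.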

Compound 4, half-maximal inhibitory concentration: 3670 nM
Compound 4: middle estimate off by 2.2-fold (0.33 log units), on the low side; the whole stated range lies below it.
By their numbers in this assay, from the lowest: compounds 3, 1, 4 and 2 (each within the scatter of the next, the first and the last beyond it).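

In this assay, the 2,4-difluorophenyl on the amine nitrogen in the ring cannot be told apart from any of the three earlier groups at this position: a 1.4-fold lower number from compound 2 to compound 4 (0.14 log units; within the scatter), a 1.9-fold higher number from compound 3 to compound 4 (0.28 log units; within the scatter) and a 1.2-fold higher number from compound 1 to compound 4 (0.09 log units; within the scatter) all lie within the scatter. For the compounds shown here, the only earlier step beyond the scatter, a 2.7-fold lower number from compound 2 to compound 3 (0.42 log units; beyond the scatter), therefore has no counterpart in the step to compound 4, and adding a second fluoro to the 4-fluorophenyl of compound 3 does not widen the separation from compound 2. Nothing available here offers an explanation for this result.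

On these data alone, it remains open whether a methoxy, a chloro or an amine on the phenyl ring would give a step beyond the scatter from compound 1. Also open, as far as these compounds go, is how a benzyl or an acetyl group on that same nitrogen would read in this assay.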